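From 6-fluoropyridin-3-yl to furan-2-yl on a shared core

A few compounds are considered here, and "the series" means these few. Any claim that something is new, unique, unknown or untested is made for them only; others in the source may bear on it.

Compound 1 `COc1ccc(S(=O)(=O)N2CCc3cccc(-c4ccc(N)cc4)c32)cc1` and compound 2 `COc1ccc(S(=O)(=O)N2CCc3cccc(-c4ccc(F)nc4)c32)cc1` share one core and differ only in the aromatic group it carries. In a functional assay on MKN-45 cells (Homo sapiens) for inhibition, with a stated time of 72 h (on this read-out lower numbers stand for stronger inhibition and higher numbers for weaker inhibition), compound 1 gives 162 nM and compound 2 gives 145 nM as its reading. These two numbers lie within the scatter of each other, so compound 2 stands level with compound 1. Compound 3 `COc1ccc(S(=O)(=O)N2CCc3cccc(-c4ccco4)c32)cc1` keeps that core, and the change furan-2-yl in place of 6-fluoropyridin-3-yl on an aromatic carbon puts furan-2-yl in place of 6-fluoropyridin-3-yl on an aromatic carbon. Among the compounds with values here, only one measured step bears on it. The step of a 1.1-fold lower number from compound 1 to compound 2 (0.05 log units; within the scatter) in this assay stays within the scatter, and it brought 6-fluoropyridin-3-yl in place of 4-aminophenyl on that same aromatic carbon. No five-membered aromatic ring has yet been measured on this core, so that single step is a thin guide. No step beyond the scatter is expected in this assay on this evidence, and neither direction is favoured. The expected step of a 1.1-fold higher number from compound 2 to compound 3 (0.04 log units; within the scatter) is accordingly small. Compound 3 is estimated at 160 nM with an expected range from 55 nM to 460 nM in this read-out.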

Compound 3, half-maximal inhibitory concentration: 42 nM
The estimate for compound 3 lay 3.8-fold (0.58 log units) above the measured number; measured number below the stated range.
By their numbers in this assay, from the lowest: compound 3; then compounds 2 and 1 (each within the scatter of the next).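

In this assay, the aromatic carbon of the shared core had shown no step beyond the scatter when 6-fluoropyridin-3-yl took the place of 4-aminophenyl, but furan-2-yl now separates from both groups (a 3.5-fold lower number from compound 2 to compound 3 (0.54 log units; beyond the scatter); a 3.9-fold lower number from compound 1 to compound 3 (0.59 log units; beyond the scatter)). This shows that the reading at this position does respond to the group it carries, and that compound 3, with its five-membered aromatic ring, gives stronger inhibition than either compound with a six-membered aromatic ring, though both steps are modest. Nothing given here accounts for the difference.

The compounds shown leave open whether the stronger inhibition goes with the five-membered ring as such, with its oxygen, or with the way furan-2-yl is joined to the core, since a single such group cannot separate these readings. Thiophen-2-yl, which swaps the oxygen for sulfur, and furan-3-yl, which keeps the oxygen but moves the point of attachment, would each test one of these possibilities on the same core.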